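This account rests on a few compounds, and the source may have more. Where it says the series, first, only, none or still open, it means among the compounds named here.

The measured compounds and their results:

Compound 1, `Cc1cc2[nH]nc(N)c2c(=O)[nH]1`, gives 56% in an assay on isolated protein for inhibition of ribosomal protein S6 kinase alpha-5 (Homo sapiens), read by mobility shift assay, tested at 30 uM; a higher number here means more inhibition at the concentration tested (going by the name of the read-out), a lower number less inhibition.
Compound 2, `Nc1n[nH]c2cc(-c3cccnc3)[nH]c(=O)c12`, gives 36% in this assay.
Compound 3, `COc1ccc(-c2cc3[nH]nc(N)c3c(=O)[nH]2)cc1`, gives 62% in this assay.

Among these three, compound 3 has the highest number. The gap to compound 1 lies within the usual scatter of such measurements, so the two cannot be ordered; the gap to compound 2 lies beyond it, and compound 2 shows the lower inhibition of the pair. The three share one core and differ only in the group attached to it.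

The next compound, compound 4, `CN1CCN(c2ccc(-c3cc4[nH]nc(N)c4c(=O)[nH]3)cc2)CC1`, is compound 3 with one change: 4-methylpiperazin-1-yl in place of methoxy on an aromatic carbon. The group sits on an aromatic carbon of a six-membered aromatic ring of carbon only, para to a large group.

Within the data shown here, no step between two measured compounds matches this change, so the expectation for compound 4 rests on compound 3 alone and on the size of the group entering. The step from compound 3 to compound 4 is expected to be small, a number 6 percentage points lower from compound 3 to compound 4 (within the scatter), and not beyond the scatter in either direction. Compound 4 is therefore estimated to give 56% in this assay, within a range from 32% to 78%.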

Compound 4, a percentage reported as inhibition, at one concentration (the size of the read-out at that concentration, not a potency): 83%
Compound 4: the middle estimate sits 27 percentage points below what was measured; measured number above the stated range.
By their numbers in this assay, from the lowest: compound 2; then compounds 1 and 3 (each within the scatter of the next); then compound 4.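

Replacing methoxy with 4-methylpiperazin-1-yl on an aromatic carbon, para to a large group, gives a number 21 percentage points higher from compound 3 to compound 4 (beyond the scatter) in this assay. Among these compounds, the earlier compounds showed only that different groups on the shared core come with different numbers, whereas this single change shows that with a much larger group, one carrying a non-aromatic ring, at this place on the six-membered aromatic ring the number in this assay is higher. Nothing at hand explains the rise, and this one step cannot separate the contributions of the ring, the added nitrogen and the methyl group of the entering substituent.

The compounds shown leave open whether a piperazine without the methyl group, a morpholine or an open-chain dimethylamino group in the same place would give a similar number, and so which part of 4-methylpiperazin-1-yl goes with the higher inhibition. They also leave open how compound 4 would rank by potency, since each number here is a reading at a single concentration, and whether the same change would have a similar effect on other kinases.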